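This account rests on a few compounds, and the source may have more. Where it says the series, first, only, none or still open, it means among the compounds named here.

Compounds measured so far:
Compound 1, `O=c1sc2cc(S(=O)(=O)c3ccccc3)ccc2n1CCN1CCCCC1`: in an assay on HEK293 cells for displacement of a labelled ligand from 5-hydroxytryptamine receptor 6 (Homo sapiens), read by radioligand binding, with a stated time of 60 min, tested at 100 nM (a lower number here means less inhibition, a higher number more inhibition at the concentration tested (going by the name of the read-out)), compound 1 gives 11%.
Compound 2, `O=c1sc2cc(S(=O)(=O)Nc3ccccc3)ccc2n1CCN1CCCC1`: in this assay compound 2 gives 37%.

Compound 2 stands highest of the two numbers; its nearest neighbour, compound 1, lies lower by a margin beyond the usual scatter. Among the measured compounds shown here, compounds 1 and 2 differ in more than one place, so no single step connects them, and their two values show only that compound 2 inhibits more at the tested concentration.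

Compound 3, `O=c1sc2cc(S(=O)(=O)Nc3ccccc3)ccc2n1CCN1CCCCC1`, is not yet measured. It differs from compound 2 by piperidin-1-yl in place of pyrrolidin-1-yl on a saturated chain carbon, two bonds along the chain from an aromatic nitrogen. No measured step of this kind exists among these compounds, so the size of the step from compound 2 to compound 3 in this assay is uncertain; the expectation is a small change, if any, most likely within the scatter, with a slight lean downward. Compound 3 is therefore expected to give about 30%, within 12% to 50%. This estimate means an expected step of a number 7 percentage points lower from compound 2 to compound 3 (within the scatter).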

Compound 3, a percentage reported as inhibition, at one concentration (the size of the read-out at that concentration, not a potency): 7%
Compound 3: middle estimate off by 23 percentage points, on the high side; measured number below the stated range.
By their numbers in this assay, from the lowest: compounds 3 and 1 (each within the scatter of the next); then compound 2.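

In this assay, the change from pyrrolidin-1-yl to piperidin-1-yl on a saturated chain carbon, two bonds along the chain from an aromatic nitrogen, gives a number 30 percentage points lower from compound 2 to compound 3 (beyond the scatter), so with anilino on the sulfonyl sulfur this position does respond to the swap of a five-membered ring for a six-membered one. With piperidin-1-yl held in place, anilino in place of phenyl on a sulfonyl sulfur gives a number 4 percentage points lower from compound 1 to compound 3 (within the scatter), so this change shows no effect that can be told from the scatter. No measured evidence accounts for either step.

As far as these compounds go, whether the ring swap gives a step of similar size with phenyl on the sulfonyl sulfur remains open. Also open, from the compounds shown here alone, is how a morpholine ring or a dimethylamino group would read at this chain position.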